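This account rests on a few compounds, and the source may have more. Where it says the series, first, only, none or still open, it means among the compounds named here.

Compound 1 (`FC(F)(F)Oc1ccc(Nc2cc(-c3ccc4[nH]ccc4c3)ncn2)cc1`) gives > 10000 nM in an ADME assay on BaF3 cells (Mus musculus) for cytotoxicity; a higher number here means that more compound is needed for the effect, a lower number that less compound is needed.
Compound 2 (`FC(F)(F)Oc1ccc(Nc2ncnc3nn(C4CCCCC4)cc23)cc1`) gives > 10000 nM in this assay.

Both of these values are limits of the assay rather than numbers: the compounds showed no toxic effect up to the highest concentration tested, so only a boundary is known. Among the compounds with values here, compound 1 therefore stands at the limit, and the one other value shown sits at the same limit, which leaves nothing to rank the two against each other. Within the data shown here, no pair of measured compounds here differs in a single place, so no measured step is available.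

Compound 3 (`FC(F)(F)Oc1ccc(Nc2cc(-c3cn[nH]c3)ncn2)cc1`) has not yet been measured. It differs from compound 1 in one place:
1H-pyrazol-4-yl in place of 1H-indol-5-yl on an aromatic carbon
The shared core and the trifluoromethoxy-substituted aniline are kept. Among the measured compounds shown here, because of the limit of > 10000 nM in this assay, at which 2 of the 2 values shown sit, the only evidence points to a step of no size beyond the scatter in this assay. Compound 3 is expected to give 15000 nM, with a range from 7000 nM to 40000 nM. The expected step is a step that the limit leaves unreadable from compound 1 to compound 3, and most likely the assay will again report only its limit.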

Compound 3, half-maximal effective concentration: > 10000 nM
Compound 3: a limit, no number; the forecaster's own chance of this, stated with the estimate: 85%; the middle value is on the limit's open side.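

In this assay compound 3 gives > 10000 nM, which is a limit of the assay and not a number. Compound 1 also sits at a limit, so the step between these two compounds cannot be read. The compounds shown leave open how much of any of them would be needed for a cytotoxic effect, and the only evidence is: the limit of > 10000 nM in this assay, at which 3 of the 3 values shown sit.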